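Bromo removal from compound 2: expected growth inhibition

This account rests on a few compounds, and the source may have more. Where it says the series, first, only, none or still open, it means among the compounds named here.

In a functional assay on MCF7 cells (Homo sapiens) for inhibition, read by spectrophotometry and sulforhodamine B assay, with a stated time of 48 h (a higher number here means a weaker inhibitor of growth, a lower number a stronger inhibitor of growth), compound 1 (`Cc1ccc(N2C(=O)CS/C2=N/N=C/c2c[nH]c3ccc(Br)cc23)cc1`) gives 59500 nM and compound 3 (`O=C1CS/C(=N/N=C/c2c[nH]c3ccc(Br)cc23)N1c1cccc2ccccc12`) gives 6060 nM while compound 2 (`S=C(N/N=C/c1c[nH]c2ccc(Br)cc12)Nc1cccc2ccccc12`) gives 950 nM as the lowest of the three numbers. Compound 3 stands nearest to compound 2 and compound 1 furthest, both gaps beyond the scatter.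

Compound 4 (`S=C(N/N=C/c1c[nH]c2ccccc12)Nc1cccc2ccccc12`) is compound 2 with hydrogen in place of bromo on an aromatic carbon. Among the compounds with values here, all three measured compounds carry the bromo, and no measured pair shows this change, so the series gives no direct size for it. The expectation is therefore loose: a moderate rise in the number, meaning a weaker inhibitor of growth, though a step within the scatter cannot be excluded. The expected step is a 2.6-fold higher number from compound 2 to compound 4 (0.42 log units; beyond the scatter) and remains an estimate. The estimate for compound 4 is 2500 nM (expected range 700 nM to 9000 nM).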

Compound 4, concentration for 50% growth inhibition: 250 nM
Estimate against measurement, compound 4: 10-fold (1.00 log units) above, and the stated range ends above it.
By their numbers in this assay, from the lowest: compound 4; then compound 2; then compound 3; then compound 1.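

In this assay, hydrogen in place of bromo gives a 3.8-fold lower number from compound 2 to compound 4 (0.58 log units; beyond the scatter), so the bromo at this aromatic carbon, meta to a fused ring and para to a fused ring, is not required for growth inhibition in the setting of compound 2. Within the data shown here, the change moves towards a stronger inhibitor by more than the scatter, a direction that the earlier compounds could not show, as all of them carry the bromo. Nothing measured bears on the origin of this step, so its cause stays unknown.

From the compounds shown here alone, whether the same change gives a step of similar direction and size on the cores of compound 1 and compound 3 stays open. Also open, going by these compounds, is how this position responds to other groups, such as chloro, methoxy or an amine on the same aromatic carbon, since this single pair compares only bromo with hydrogen.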